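A few compounds are considered here, and "the series" means these few. Any claim that something is new, unique, unknown or untested is made for them only; others in the source may bear on it.

Of the compounds shown here, three sharing one core have been measured in an assay on isolated protein for inhibition of leukotriene B4 receptor 1 (Homo sapiens), tested at 10 uM; on this read-out lower numbers stand for less inhibition and higher numbers for more inhibition at the one concentration tested (going by the name of the read-out). Compound 1 `C=CCc1cc(C(C)=O)c(O)cc1OCCCCCCCC#N` gives 88%. Compound 3 `C=CCCCCOc1cc(O)c(C(C)=O)cc1CC=C` gives 73%; the change on the chain from compound 1 to compound 3 is a vinyl in place of 3-cyanopropyl, and the measured step is a number 15 percentage points lower from compound 1 to compound 3 (beyond the scatter). Compound 2 `CCc1cc(C(C)=O)c(O)cc1OCCCCCCC(C)(C)C#N` gives 65%, the lowest of the three numbers; its gap to compound 3 lies within the scatter, while its gap to compound 1 lies beyond it.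

Compound 4 `CCc1cc(C(C)=O)c(O)cc1OCCCCc1nnn[nH]1` is not yet measured. It differs from compound 2 in one place: 1H-tetrazol-5-yl in place of 3-cyano-3-methylbutyl on a saturated chain carbon, four bonds along the chain from an oxygen on an aromatic ring. Among the measured compounds shown here, only one measured step touches the same place on the chain, the one from compound 1 to compound 3, and it shows that exchanging the group at that position moved the inhibition by a modest amount in one instance. That step concerns a different pair of groups, so it gives a size but not a direction for the present change. Compound 4 is therefore expected to stay close to compound 2, with a step of a number 5 percentage points higher from compound 2 to compound 4 (within the scatter) that may fall within the scatter. The estimate for compound 4 is 70%, with a range from 45% to 90%.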

Compound 4, a percentage reported as inhibition, at one concentration (the size of the read-out at that concentration, not a potency): 49%
For compound 4 the middle estimate is 21 percentage points above the measured one; the measured number falls inside the stated range.
By their numbers in this assay, from the lowest: compound 4; then compounds 2 and 3 (each within the scatter of the next); then compound 1.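

In this assay, among the compounds shown here, the exchange of 3-cyano-3-methylbutyl for 1H-tetrazol-5-yl gives a direction that the earlier compounds could not supply for this change: a number a number 16 percentage points lower from compound 2 to compound 4 (beyond the scatter). This is the second exchange at this place on the chain to move the read-out beyond the scatter, and it does so on the core of compound 2, so the position is sensitive to its group in two separate pairs, and in both the number falls. Compound 4 keeps a measurable inhibition of 49% with a ring carrying a hydrogen-bond donor in place of the nitrile chain, yet nothing available accounts for the drop.

Chain and end group change together in this step, so the share of each in the fall stays unknown. A carboxylic acid at the same place, or a longer chain ending in the tetrazole ring, would be needed to pull the two apart.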